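The compounds below may be only part of what the source reports. "The series", "measured", "known", "first", "only" and "open" are said of these compounds alone.

In an ADME assay on the whole organism (strain CD-1) for pharmacokinetics, with Mus musculus as the target, at a dose of 3 mg/kg by the intravenous route (a higher number here means more compound in the circulation at the dose given, a lower number less compound in the circulation), compound 1 (`CN(Cc1ccccc1OCCC[C@@H]1C[C@@H]1C(=O)O)C(=O)c1ccc(-c2ccco2)cc1`) stands highest of the two measured at 30100 ng.h/mL and compound 2 (`CN(Cc1ccccc1OCCC/C=C/C(=O)O)C(=O)c1ccc(-c2ccco2)cc1`) gives 750 ng.h/mL on the same read-out. The change to compound 3 (`C/C(=C\C(=O)O)CCCOc1ccccc1CN(C)C(=O)c1ccc(-c2ccco2)cc1`) is 2-carboxy-1-methylethenyl in place of 2-carboxycyclopropyl on a saturated chain carbon, three bonds along the chain from an oxygen on an aromatic ring with no ring left in that group. Going by the values given here, the one measured step that bears on it is a 40-fold lower number from compound 1 to compound 2 (1.60 log units; beyond the scatter) which is large and also gives up 2-carboxycyclopropyl for an open 2-carboxyethenyl group. Among the compounds with values here, no measured step covers the added methyl. A large step down in this assay is therefore expected, estimated as a 20-fold lower number from compound 1 to compound 3 (1.30 log units; beyond the scatter) for now. Compound 3 is estimated at 1500 ng.h/mL within an expected range of 400 ng.h/mL to 6000 ng.h/mL for this read-out.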

Compound 3, area under the concentration-time curve: 4700 ng.h/mL
Estimate against measurement, compound 3: 3.1-fold (0.50 log units) below, and the stated range covers the measured number.
By their numbers in this assay, from the lowest: compound 2; then compound 3; then compound 1.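

In this assay the open group does not stay at the level of compound 2: the added methyl of 2-carboxy-1-methylethenyl gives a 6.3-fold higher number from compound 2 to compound 3 (0.80 log units; beyond the scatter), so a substituent on the double bond changes the read-out at this position. The ring is still not matched, with a 6.4-fold lower number from compound 1 to compound 3 (0.81 log units; beyond the scatter) for the same atoms joined differently. Nothing at hand explains either step.

Going by these compounds, whether a saturated chain ending in a carboxylic acid, or a cyclobutane ring carrying that acid, would stand nearer compound 1 or compound 2 remains open. So does the reading for 2-carboxy-1-methylethenyl with the other double-bond geometry.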